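The source may report more compounds than this note shows. Statements on the series, on what has been measured and on what is new or still open speak of the compounds shown alone.

Measured compounds:
compound 1 `CC(C)CCn1ccc(OCc2ccccc2)c(C#N)c1=O` — 2950 nM
compound 2 `N#Cc1c(N2CCC(c3ccccc3)CC2)ccn(CC2CC2)c1=O` — 151 nM
compound 3 `O=c1c(Cl)c(N2CCC(c3ccccc3)CC2)ccn1CC1CC1` — 170 nM

In a functional assay on CHO cells for positive allosteric modulation of metabotropic glutamate receptor 2 (Homo sapiens), with a stated time of 30 min (on this read-out lower numbers stand for an effect already at smaller amounts and higher numbers for an effect only at larger amounts of compound), compound 3 stands second highest of the three numbers. Compound 2 sits within the scatter of it, a 1.1-fold higher number from compound 2 to compound 3 (0.05 log units; within the scatter), whereas compound 1 gives a number beyond the scatter higher than compound 3.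

Compound 4 `O=c1c(C(F)(F)F)c(N2CCC(c3ccccc3)CC2)ccn1CC1CC1` differs from compound 3 by trifluoromethyl in place of chloro on an aromatic carbon. Among the measured compounds shown here, the only step measured at this position of the shared core is a 1.1-fold higher number from compound 2 to compound 3 (0.05 log units; within the scatter), which did not leave the scatter; no measured step carries a trifluoromethyl group. On that basis no step beyond the scatter is expected in this assay, as a 1.2-fold higher number from compound 3 to compound 4 (0.07 log units; within the scatter). Compound 4 is therefore estimated at 200 nM, with a range from 70 nM to 600 nM.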

Compound 4, half-maximal effective concentration: 251 nM
Compound 4: middle estimate off by 1.3-fold (0.10 log units), on the low side; measured number inside the range.
By their numbers in this assay, from the lowest: compounds 2, 3 and 4 (each within the scatter of the next); then compound 1.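

In this assay the position now holds a third group, with a 1.5-fold higher number from compound 3 to compound 4 (0.17 log units; within the scatter) and a 1.7-fold higher number from compound 2 to compound 4 (0.22 log units; within the scatter) so cyano, chloro and trifluoromethyl cannot be told apart here. Trifluoromethyl, with 4 heavy atoms against 1 for chloro, still leaves the number within the scatter of both earlier groups. No measured property bears on this result.

Open, as far as these compounds go, is whether an amine or a carboxylic acid at this position would also stay within the scatter. Also open, from the compounds shown here alone, is whether these three groups stay level with a longer chain in place of the cyclopropylmethyl group.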